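Swapping isopropyl for trifluoromethyl on compound 3

The source may hold more compounds than are shown below. What is called first, only, known or untested is meant among the compounds shown, and "the series" means these compounds.

Compound 1, `O=C(Nc1nnc(-c2ccc(Cl)cc2)s1)c1ccccc1Br`: in a functional assay on the whole organism (integument) for inhibition, with Chilo suppressalis as the target, read by scintillation counting, with a stated time of 72 h (a lower number here means a stronger inhibitor, a higher number a weaker inhibitor), compound 1 reaches only a limit of the assay, > 5010 nM.
Compound 2, `COc1ccccc1C(=O)Nc1nnc(-c2ccc(Cl)cc2)s1`: in this assay compound 2 gives 53.7 nM.
Compound 3, `COc1cccc(OC)c1C(=O)Nc1nnc(-c2ccc(C(C)C)cc2)s1`: in this assay compound 3 gives 398 nM.

Among the two real numbers, compound 3 stands highest, which here means the weaker inhibitor. Its nearest neighbour is compound 2, but the two differ in more than one place, so their values can only be set side by side, not read as a single step.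

The unmeasured compound 4, `COc1cccc(OC)c1C(=O)Nc1nnc(-c2ccc(C(F)(F)F)cc2)s1`, differs from compound 3 by one change: trifluoromethyl in place of isopropyl on an aromatic carbon.

Among the measured compounds shown here, the only single-point step measured so far is an at least 93-fold lower number from compound 1 to compound 2 (1.96 log units; beyond the scatter), and that step sits on the other aromatic ring of the shared core, not at the position para to the large group. It also starts from compound 1, whose value is only (the limit of > 5010 nM in this assay, at which 1 of the 3 values shown sits), so even its size is a lower bound. For the measured compounds named here, no measured step therefore bears directly on the change from compound 3 to compound 4, and nothing in the data points to a move in either direction.

The expectation is a step of about a 1.1-fold lower number from compound 3 to compound 4 (0.06 log units; within the scatter), that is, none beyond the scatter. Compound 4 is estimated at 350 nM in this assay, with a likely range from 80 nM to 1500 nM.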

Compound 4, half-maximal inhibitory concentration: 49 nM
The estimate for compound 4 lay 7.1-fold (0.85 log units) above the measured number, outside the stated range (below it).
By their numbers in this assay, from the lowest: compounds 4 and 2 (each within the scatter of the next); then compound 3. At a limit, above all of these: compound 1.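

Among the compounds shown here, the change of trifluoromethyl for isopropyl gives an 8.1-fold lower number from compound 3 to compound 4 (0.91 log units; beyond the scatter) in this assay, the first measured step at this place, on an aromatic carbon para to a large group. It shows that the group here affects the reading, so this is not a place where one group can be exchanged for another without consequence. Neither group carries a hydrogen-bond donor, a hydrogen-bond acceptor or a net charge, so those counts do not separate them, and nothing measured here accounts for the size of the step.

Going by these compounds, with only isopropyl and trifluoromethyl compared on this shared core, it remains open how a nitrile, an amine, a carboxylic acid or a longer chain such as butyl would read at the same place. Chloro appears at this place only in compound 1 and compound 2, which also differ from compound 4 elsewhere, so how chloro compares with trifluoromethyl on the core of compound 4 also remains open.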